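Side-chain isomer of an acetylated labdane glycoside

The source may hold more compounds than are shown below. What is called first, only, known or untested is meant among the compounds shown, and "the series" means these compounds.

Measured so far:
compound 1, `CC1=CCC[C@@H]2[C@@](C)(CC/C(C)=C/CO)[C@H](C)C[C@H](O[C@@H]3O[C@@H](C)[C@H](O[C@@H]4O[C@H](CO)[C@@H](O)[C@H](O)[C@H]4O)[C@@H](O)[C@H]3O)[C@@]12C`, giving 325000 nM in an ADME assay on C8166 cells (Homo sapiens) for cytotoxicity, read by MTT assay; on this read-out lower numbers stand for higher toxicity in this test and higher numbers for lower toxicity in this test;
compound 2, `C[C@@H]1C[C@H](O)[C@@]2(C)C(CO)=CCC[C@@H]2[C@@]1(C)CC(=O)O`, giving 709000 nM in this assay;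
compound 3, `CC(=O)OC[C@H]1O[C@@H](O[C@@H]2[C@@H](O)[C@@H](O)[C@H](O[C@H]3C[C@@H](C)[C@](C)(CC/C(C)=C/CO)[C@H]4CCC=C(C)[C@]34C)O[C@H]2C)[C@H](O)[C@@H](O)[C@@H]1O`, giving 136000 nM in this assay.

Compound 3 has the lowest number of the three, so it is the most cytotoxic compound measured here: compound 1 lies a 2.4-fold lower number from compound 1 to compound 3 (0.38 log units; beyond the scatter) behind it, and compound 2 sits furthest away with a higher number still. For the measured compounds named here, the only step measured between compounds that differ in a single place is that from compound 1 to compound 3, which was modest.

Compound 4, `C=C[C@](C)(O)CC[C@@]1(C)[C@H](C)C[C@H](O[C@@H]2O[C@@H](C)[C@H](O[C@@H]3O[C@H](COC(C)=O)[C@@H](O)[C@H](O)[C@H]3O)[C@@H](O)[C@H]2O)[C@@]2(C)C(C)=CCC[C@H]12`, keeps the acetylated sugar of compound 3 and changes only the side chain: 1-hydroxy-1-methylprop-2-en-1-yl in place of 3-hydroxy-1-methylprop-1-en-1-yl on a saturated chain carbon, two bonds along the chain from a saturated ring carbon. Going by the values given here, no measured pair covers a rearrangement of this kind, so the one step on record gives no direct guidance. Since the sugar part and the core are unchanged, compound 4 is expected to stay close to compound 3, with a 1.0-fold higher number from compound 3 to compound 4 (0.01 log units; within the scatter) lying within the scatter. For compound 4 the estimated value in this assay is 140000 nM, ranging from 60000 nM to 330000 nM.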

Compound 4, half-maximal cytotoxic concentration: 121000 nM
Compound 4: middle estimate off by 1.2-fold (0.06 log units), on the high side, within the range that was stated.
By their numbers in this assay, from the lowest: compounds 4 and 3 (each within the scatter of the next); then compound 1; then compound 2.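

The side-chain exchange at this position gives a 1.1-fold lower number from compound 3 to compound 4 (0.05 log units; within the scatter) in this assay, so compound 3 and compound 4 cannot be told apart in this test. The earlier compounds shown here showed a single step, at the sugar; this result adds that on a saturated chain carbon, two bonds along the chain from a saturated ring carbon, the 3-hydroxy-1-methylprop-1-en-1-yl group can give way to its isomer, with its defined stereocentre, and the read-out stays within the scatter. No supporting data bear on why the read-out holds here.

The compounds shown leave open whether a carboxylic acid or an amine in place of the hydroxyl, or a longer chain at this position, would read differently. They also leave open whether the same exchange gives the same result on the sugar without its acetyl group, as carried by compound 1.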